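Succinate receptor antagonists: fluoro for trifluoromethyl on the aryl ring

The compounds below may be only part of what the source reports. "The series", "measured", "known", "first", "only" and "open" are said of these compounds alone.

Measured so far in a functional assay on CHO-K1 cells for antagonist activity at succinate receptor 1 (Homo sapiens), read by FLIPR and calcium flux; a higher number here means a weaker inhibitor, a lower number a stronger inhibitor:
compound 1 `CCc1cccc(-c2ccc(CNC(=O)CCCc3ccc4cccnc4n3)cc2)c1` gives 65 nM
compound 2 `FC(F)(F)c1ccc(-c2nnc(CCCCc3ccc4cccnc4n3)o2)cc1` gives 3000 nM
compound 3 `FC(F)(F)c1ccc(-c2nnc(CCCCc3ccc4cccnc4n3)o2)cc1C(F)(F)F` gives 170 nM

Compound 3 stands second highest of the three numbers in this assay; compound 1 is nearest with a lower number, compound 2 furthest with a higher one. For the measured compounds named here, the only single-point step recorded is an 18-fold lower number from compound 2 to compound 3 (1.25 log units; beyond the scatter), a large gain from putting a second trifluoromethyl onto the aryl ring.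

Compound 4 `Fc1ccc(-c2nnc(CCCCc3ccc4cccnc4n3)o2)cc1C(F)(F)F` is not yet measured. It differs from compound 3 by fluoro in place of trifluoromethyl on an aromatic carbon. Going by the values given here, no measured step covers this change: compound 2 differs from compound 4 at two points, so the pair only shows that compound 2 without the second trifluoromethyl sits far higher than compound 3. The exchange shrinks the group that compound 2 already carries, and it is not the group whose removal gave the large step. A modest rise in the number is therefore expected, a 1.8-fold higher number from compound 3 to compound 4 (0.25 log units; within the scatter), possibly within the scatter. Compound 4 is estimated at 300 nM, with a range from 100 nM to 1200 nM.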

Compound 4, half-maximal inhibitory concentration: 2000 nM
Beside the measured number, compound 4's estimate is 6.7-fold (0.82 log units) below it, outside the stated range (above it).
By their numbers in this assay, from the lowest: compound 1; then compound 3; then compounds 4 and 2 (each within the scatter of the next).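

In this assay fluoro takes the place of the trifluoromethyl para to a large group. The step is a 12-fold higher number from compound 3 to compound 4 (1.07 log units; beyond the scatter), a large loss, and one heavy atom stands where four stood. For the compounds shown here, earlier, the only measured step at a trifluoromethyl site was an 18-fold lower number from compound 2 to compound 3 (1.25 log units; beyond the scatter) and it covered the other group, so the low number of compound 3 now proves to depend on both trifluoromethyl groups, not on the added one alone. Nothing measured here explains the size of this loss.

Open, going by these compounds, is what a chloro, a methyl or a nitrile would give at this carbon with the other trifluoromethyl kept, which would separate heavy-atom count from the identity of the group. On these data alone, whether the same substitution holds on the core of compound 1 also remains open.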